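This account rests on a few compounds, and the source may have more. Where it says the series, first, only, none or still open, it means among the compounds named here.

Measured so far:
- compound 1, `Nc1cc(N)c2nc(-c3ccccc3)c(Oc3ccc(Cl)c(Cl)c3)nc2c1`: 39800 nM
- compound 2, `CCOC(=O)[C@H](CCC(=O)O)NC(=O)c1ccc(Sc2nc3cc(N)cc(N)c3nc2-c2ccccc2)cc1`: 33900 nM

Both numbers come from a functional assay on NCI-H23 cells (Homo sapiens) for inhibition, read by sulforhodamine B assay, with a stated time of 48 h; a lower number here means a stronger inhibitor of growth, a higher number a weaker inhibitor of growth. Compound 1 stands at 39800 nM and compound 2 at 33900 nM; the gap between them lies within the usual scatter, so the two cannot be told apart on these data, and both sit in the weak range of this assay. Among the measured compounds shown here, no step between measured compounds that differ in one place is available, so the series gives no guide to how changes on the aryl ether arm move the number.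

Compound 3, `Nc1cc(N)c2nc(-c3ccccc3)c(Oc3ccc(F)cc3)nc2c1`, is still to be measured in this assay. It differs from compound 1 as follows: 4-fluorophenyl in place of 3,4-dichlorophenyl on an oxygen on an aromatic ring. With nothing measured on this arm, the expectation for the step from compound 1 to compound 3 is a 1.1-fold higher number from compound 1 to compound 3 (0.05 log units; within the scatter), that is, no change beyond the scatter, with a wide range to allow for a modest shift either way. Compound 3 is therefore estimated at 45000 nM, within 15000 nM to 140000 nM.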

Compound 3, concentration for total growth inhibition: 39800 nM
Compound 3: middle estimate off by 1.1-fold (0.05 log units), on the high side; the measured number falls inside the stated range.
By their numbers in this assay, from the lowest: compounds 2, 1 and 3 (each within the scatter of the next).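

Among the compounds shown here, on the aryl ether arm of the shared core, in this assay, 4-fluorophenyl in place of 3,4-dichlorophenyl gives no change at the digits printed from compound 1 to compound 3 (within the scatter), the first step that can be read at this position. Exchanging the two chlorines for a single fluorine on this phenyl ring thus leaves the number unmoved, and compound 3 stays in the weak range of the assay alongside compound 1. No measurement at hand speaks to the reason for this result.

Open, as far as these compounds go, is whether a phenyl ring carrying an amine or a carboxylic acid, or a longer chain on the same oxygen, would move the number beyond the scatter. Compound 2 differs from compound 1 in more than one place, so it offers no reading on this arm.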